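The compounds below may be only part of what the source reports. "The series", "measured", "known", "first", "only" and "open" are said of these compounds alone.

In a functional assay on HUVEC cells (Homo sapiens), read by BrdU incorporation, with a stated time of 72 h (on this read-out higher numbers stand for weaker inhibition and lower numbers for stronger inhibition), compound 1 `Cc1ccc2nc(Cl)c(/C=C/C(=O)c3sccc3C)cc2c1`, which carries a 3-methylthiophen-2-yl on the carbonyl carbon, gives 127 nM. Compound 2 `Cc1ccc2nc(Cl)c(/C=C/C(=O)c3ccc(Cl)s3)cc2c1`, which carries a 5-chlorothiophen-2-yl there, gives 59.4 nM. Compound 3 `Cc1ccc2cc(/C=C/C(=O)c3ccc(Cl)s3)c(Cl)nc2c1`, with the same 5-chlorothiophen-2-yl, gives 49.5 nM. Compound 2 and compound 3 therefore stand level within the scatter, and compound 2 is separated only from compound 1. For the measured compounds named here, that separation is the one measured step, a 2.1-fold lower number from compound 1 to compound 2 (0.33 log units; beyond the scatter), which is modest and only just beyond the scatter.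

Compound 4 `Cc1ccc2nc(Cl)c(/C=C/C(=O)c3sccc3Cl)cc2c1` is the next to be examined. It has 3-chlorothiophen-2-yl in place of the 5-chlorothiophen-2-yl of compound 2 on a carbonyl carbon, (3-chlorothiophen-2-yl in place of 5-chlorothiophen-2-yl on a carbonyl carbon). Going by the values given here, the only measured guide is the step to compound 2 read in reverse, setting the 3-chlorothiophen-2-yl of compound 4 alongside the 3-methylthiophen-2-yl of compound 1 at 127 nM. Among the compounds with values here, no measured pair compares these two groups directly, so the guide is a loose one. In this assay, the expected change is a 1.7-fold higher number from compound 2 to compound 4 (0.23 log units; within the scatter), a modest rise that may stay within the scatter. For compound 4 the estimated value is 100 nM, with an expected range from 40 nM to 230 nM.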

Compound 4, half-maximal inhibitory concentration: 37.5 nM
Beside the measured number, compound 4's estimate is 2.7-fold (0.43 log units) above it; the whole stated range lies above it.
By their numbers in this assay, from the lowest: compounds 4, 3 and 2 (each within the scatter of the next); then compound 1.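

Compound 4 separates two things that the step from compound 1 to compound 2 had changed together, the identity of the group and where it sits on the thiophene. With the group kept as chloro, the 3-chlorothiophen-2-yl and 5-chlorothiophen-2-yl on the carbonyl carbon stand level in this assay, at a 1.6-fold lower number from compound 2 to compound 4 (0.20 log units; within the scatter), so the shift of the chloro gives no measurable change here, whereas chloro in place of methyl on an aromatic carbon, with the place unchanged, gives a 3.4-fold lower number from compound 1 to compound 4 (0.53 log units; beyond the scatter), which is beyond the scatter and shows that, in this one pair, the identity of the group separates the compounds. Nothing available explains why chloro and methyl differ in this way.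

The compounds shown leave open whether a 5-methylthiophen-2-yl would match its 3-methylthiophen-2-yl counterpart in compound 1 as closely as the two chloro isomers match each other, and whether a bromo or methoxy group at either place would stand with chloro or with methyl. They also leave open whether the 3-chlorothiophen-2-yl would behave the same way on the core of compound 3, and whether an amine on the thiophene would be tolerated at all.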